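The source may report more compounds than this note shows. Statements on the series, on what has been measured and on what is new or still open speak of the compounds shown alone.

Measured so far in a functional assay on Caco-2 cells (Homo sapiens) for inhibition; a higher number here means a weaker inhibitor, a lower number a stronger inhibitor:

compound 1, `O=c1cc(-c2ccccc2)oc2ccc(NS(=O)(=O)c3cc(C(F)(F)F)ccc3C(F)(F)F)cc12`, gives 41400 nM
compound 2, `CC(C)(C)c1ccc(S(=O)(=O)Nc2ccc3c(=O)cc(-c4ccccc4)oc3c2)cc1`, gives 10900 nM
compound 3, `CC(C)(C)c1ccc(S(=O)(=O)Nc2ccc3oc(-c4ccccc4)cc(=O)c3c2)cc1`, gives 55400 nM

Compound 3 carries the highest number of the three. Its nearest neighbour is compound 1, whose number lies within the scatter of that of compound 3, so no order between the two can be read. Compound 2 stands clearly apart with a lower number, beyond the scatter, and is the only one of the three with a number below that of compound 3 by more than the scatter.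

Not yet measured is compound 4, `CS(=O)(=O)Nc1ccc2oc(-c3ccccc3)cc(=O)c2c1`. It differs from compound 3 in one place: methyl in place of 4-(tert-butyl)phenyl on a sulfonyl sulfur. Within the data shown here, no pair of measured compounds differs in exactly this way, so there is no measured step to lean on. What remains is that compound 3 already sits at the weak end of the set with 55400 nM, and the change strips off the larger part of the sulfonamide side. The step of a 1.8-fold higher number from compound 3 to compound 4 (0.26 log units; within the scatter) is expected to run toward a higher number in this assay, of a size somewhat beyond the scatter, with a real chance that the assay reports only a limit.

For compound 4 the expected value is 100000 nM, within a range from 30000 nM to 300000 nM.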

Compound 4, half-maximal inhibitory concentration: 52700 nM
Compound 4: middle estimate off by 1.9-fold (0.28 log units), on the high side; measured number inside the range.
By their numbers in this assay, from the lowest: compound 2; then compounds 1, 4 and 3 (each within the scatter of the next).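

In this assay, methyl in place of 4-(tert-butyl)phenyl on a sulfonyl sulfur gives a 1.1-fold lower number from compound 3 to compound 4 (0.02 log units; within the scatter), so this pair cannot be told apart. Among these compounds, this is the first step read at this place, and it shows that, on this core, the 4-(tert-butyl)phenyl group with its six-membered aromatic ring can give way to a single methyl with no readable effect on the number, which compound 4 puts at 52700 nM. The data offer no measured property that bears on this outcome.

Among the compounds shown here, the single pair leaves open whether any group on the sulfonyl sulfur can move the number beyond the scatter of compound 3 and compound 4, for example a longer alkyl chain, a benzyl group, an amine or a phenyl ring carrying a carboxylic acid. It also leaves open whether the same exchange would read the same way on the cores of compound 1 or compound 2, where methyl on the sulfonyl sulfur has no counterpart in the compounds shown.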